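This account rests on a few compounds, and the source may have more. Where it says the series, first, only, none or still open, it means among the compounds named here.

Compound 1 `C=C(Br)C(=O)Nc1cccc(/C=C2\SC(=O)N(Cc3ccc(C)cc3)C2=O)c1` is the reference point of this account. In a functional assay on CCRF-CEM cells (Homo sapiens) for cytotoxicity, read by cell counting, with a stated time of 3 days (a higher number here means a weaker inhibitor, a lower number a stronger inhibitor), compound 1 gives 1200 nM, which is the lowest of the two numbers reported, with compound 2 `Nc1ccc(/C=C2\SC(=O)N(Cc3cccc(Cl)c3)C2=O)cc1` as its nearest neighbour at 18000 nM in this assay. Compound 3 `Cc1ccc(CN2C(=O)S/C(=C\c3ccc(N)cc3)C2=O)cc1` returns only a limit in this assay, > 250000 nM, so its strength is not given as a number. The one measured step among these compounds, an at least 13-fold higher number from compound 2 to compound 3 (1.14 log units; beyond the scatter), touches the benzyl substituent on the amide-type ring nitrogen, and it rests on the limit of > 250000 nM in this assay, at which 1 of the 3 values shown sits, rather than on a measured number.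

The unmeasured compound 4 `C=C(Br)C(=O)Nc1cccc(/C=C2\SC(=O)N(Cc3ccc(C(C)(C)C)cc3)C2=O)c1` differs from compound 1 in that same benzyl group: tert-butyl in place of methyl on an aromatic carbon. Among the compounds with values here, no measured step here exchanges one alkyl group for another on that ring, and the one step that does exist swaps a 3-chlorophenyl for a 4-methylphenyl, a different kind of change, so it bears on compound 4 only loosely. The expectation for compound 4 is therefore a step in this assay that stays near or within the scatter, with no clear direction, as expressed by a 1.3-fold higher number from compound 1 to compound 4 (0.10 log units; within the scatter). Compound 4 is estimated at 1500 nM in this assay, within a range from 400 nM to 6000 nM.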

Compound 4, half-maximal inhibitory concentration: 3000 nM
For compound 4 the middle estimate is 2.0-fold (0.30 log units) below the measured one, within the range that was stated.
By their numbers in this assay, from the lowest: compound 1; then compound 4; then compound 2. At a limit, above all of these: compound 3.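

In this assay the exchange of 4-methylphenyl for 4-(tert-butyl)phenyl gives a 2.5-fold higher number from compound 1 to compound 4 (0.40 log units; beyond the scatter) and so puts a measured size on a change at this aromatic carbon, with the rest of compound 1 held fixed. Within the data shown here, the one earlier step on this benzyl group ended at a limit and exchanged a chlorine-bearing ring, whereas this one has a number at both ends and shows that four heavy atoms in place of one shift the number only modestly. Nothing among the data shown speaks to why the number moves in this direction.

Left open is how smaller alkyl groups such as ethyl or isopropyl would read at this aromatic carbon, and whether a hydroxyl, a carboxylic acid or an amine there would move the number in this assay the same way. Also open, on these data alone, is whether tert-butyl in place of methyl would give a step of similar size on a compound that keeps the amine of compound 3 rather than the amide side chain of compound 1.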